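Vero cytotoxicity of ester and sulfonate variants

This account rests on a few compounds, and the source may have more. Where it says the series, first, only, none or still open, it means among the compounds named here.

Measured so far:
Compound 1 `O=C(OC1CCC(CN2CCN(c3cc(=O)c4cc(C(F)(F)F)cc([N+](=O)[O-])c4s3)CC2)CC1)c1ccco1` — in an ADME assay on Vero cells (Chlorocebus sabaeus) for cytotoxicity, read by MTT assay, with a stated time of 48 h (on this read-out lower numbers stand for stronger inhibition and higher numbers for weaker inhibition), compound 1 gives > 64 ug/mL, a limit of the assay.
Compound 2 `O=c1cc(N2CCN(CC3CCC(OS(=O)(=O)c4ccccc4)CC3)CC2)sc2c([N+](=O)[O-])cc(C(F)(F)F)cc12` — in this assay compound 2 gives > 64 ug/mL, a limit of the assay.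
Compound 3 `O=C(OC1CCC(CN2CCN(c3cc(=O)c4cc(C(F)(F)F)cc([N+](=O)[O-])c4s3)CC2)CC1)c1ccccc1` — in this assay compound 3 gives > 64 ug/mL, a limit of the assay.

Compound 2 therefore stands only at a limit, with no number of its own; the two other values shown are limits as well, so nothing places it above or below them. The steps between the measured compounds share this fate: a step that the two limits leave unreadable from compound 1 to compound 2, a step that the two limits leave unreadable from compound 2 to compound 3 and a step that the two limits leave unreadable from compound 1 to compound 3 are all unreadable because every value involved sits at the limit of > 64 ug/mL in this assay, at which 3 of the 3 values shown sit.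

The next compound, compound 4 `COc1cccc(C(=O)OC2CCC(CN3CCN(c4cc(=O)c5cc(C(F)(F)F)cc([N+](=O)[O-])c5s4)CC3)CC2)c1`, differs from compound 2 in one place: (3-methoxyphenyl)carbonyl in place of phenylsulfonyl on an oxygen on a saturated carbon. The closest measured comparison is the change from compound 2 to compound 3, where a benzoyl replaces the phenylsulfonyl on the same oxygen; compound 4 adds a methoxy to that benzoyl. For the measured compounds named here, since none of the measured steps resolves a size or direction, no step beyond the scatter is expected in this assay, and a number no higher from compound 2 to compound 4 (the limit leaves the size open) is set at no change. Compound 4 is expected to give 64 ug/mL (range 32 ug/mL to 64 ug/mL), most likely reported as a limit again.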

Compound 4, half-maximal inhibitory concentration: > 64 ug/mL
Compound 4: no number, only a limit; the forecaster's own chance of this, stated with the estimate: 85%; the middle value lies on the limit itself.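

In this assay compound 4 gives > 64 ug/mL, a limit of the assay. No step from compound 1, compound 2 or compound 3 to compound 4 can be read, because all the values sit at one limit: the limit of > 64 ug/mL in this assay, at which 4 of the 4 values shown sit.

The compounds shown leave open whether the groups on this oxygen differ at all in cytotoxicity.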